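Swapping sulfamoyl for methylsulfonyl on a chloro-substituted core

The compounds below may be only part of what the source reports. "The series", "measured", "known", "first", "only" and "open" are said of these compounds alone.

Compound 1, `Cc1ccc2nc(Nc3nc(Nc4ccc(S(N)(=O)=O)cc4)ncc3F)sc2c1`: 6390 nM
Compound 2, `Cc1ccc2nc(Nc3nc(Nc4ccc(S(C)(=O)=O)cc4)ncc3F)sc2c1`: 14300 nM
Compound 3, `NS(=O)(=O)c1ccc(Nc2ncc(F)c(Nc3nc4ccc(Cl)cc4s3)n2)cc1`: 2790 nM

These three were tested in a functional assay on MDA-MB-231 cells (Homo sapiens) for antiproliferative activity, read by MTT assay, with a stated time of 48 h; on this read-out lower numbers stand for stronger inhibition and higher numbers for weaker inhibition. Compound 3 gives the lowest number of the set, reached by a 2.3-fold lower number from compound 1 to compound 3 (0.36 log units; beyond the scatter); the difference between the core of compound 1 and the core of compound 3 is chloro in place of methyl on an aromatic carbon. Compound 4, `CS(=O)(=O)c1ccc(Nc2ncc(F)c(Nc3nc4ccc(Cl)cc4s3)n2)cc1`, has not yet been measured. It differs from compound 3 in one place: methyl in place of amino on a sulfonyl sulfur. The same change was already made once, from compound 1 to compound 2, where it is methyl in place of amino on a sulfonyl sulfur and gave a 2.2-fold higher number from compound 1 to compound 2 (0.35 log units; beyond the scatter). The surroundings of the place are described in identical words in both cases, so this counts as the same change. Because the earlier step was a 2.2-fold higher number from compound 1 to compound 2 (0.35 log units; beyond the scatter), a step of similar size is expected here, a 2.2-fold higher number from compound 3 to compound 4 (0.34 log units; beyond the scatter). Compound 4 is therefore estimated at 6100 nM, with a likely range from 3000 nM to 13000 nM.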

Compound 4, half-maximal inhibitory concentration: 11100 nM
Beside the measured number, compound 4's estimate is 1.8-fold (0.26 log units) below it; the range from low to high includes it.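

In this assay methyl in place of amino on the sulfonyl sulfur of the chloro-substituted core gives a 4.0-fold higher number from compound 3 to compound 4 (0.60 log units; beyond the scatter) and so points the same way as on the methyl-substituted core, with the two steps no further apart than repeat measurements allow: the same change on two cores in this assay, a 2.2-fold higher number (0.35 log units; beyond the scatter) from compound 1 to compound 2 and a 4.0-fold higher number (0.60 log units; beyond the scatter) from compound 3 to compound 4, 1.8-fold (0.25 log units) apart, within the scatter of two such steps. Chloro in place of methyl, read on the methylsulfonyl compounds, gives a 1.3-fold lower number from compound 2 to compound 4 (0.11 log units; within the scatter) and also does not separate from its earlier step: the same change on two cores in this assay, a 2.3-fold lower number (0.36 log units; beyond the scatter) from compound 1 to compound 3 and a 1.3-fold lower number (0.11 log units; within the scatter) from compound 2 to compound 4, 1.8-fold (0.25 log units) apart, within the scatter of two such steps. These two cores show that each change carried over here, but they do not show that it would carry over to any other core.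

From the compounds shown here alone, whether the step would look the same with an ethyl chain or a dimethylamino group on the sulfonyl sulfur remains open. So does the outcome with bromo or methoxy in place of the chloro.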